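Replacing a pyrrole ring: what to expect for compound 3

The source may report more compounds than this note shows. Statements on the series, on what has been measured and on what is new or still open speak of the compounds shown alone.

Compound 1: `Cn1nc2c(=O)n(CC3(O)CCN(Cc4ccc(-c5ccc[nH]5)cc4Cl)CC3)cnc2c1-c1ccc(CN)cc1` — 193 nM
Compound 2: `Cn1nc2c(=O)n(CC3(O)CCN(Cc4ccc(-c5ccco5)cc4Cl)CC3)cnc2c1-c1ccc(CO)cc1` — 42.5 nM

Both compounds share the same core and were tested in an assay on isolated protein for inhibition of ubiquitin carboxyl-terminal hydrolase 7 (Homo sapiens), with stated times of 30 min and 2 h; on this read-out higher numbers stand for weaker inhibition and lower numbers for stronger inhibition. Compound 1 gives 193 nM, the higher of the two numbers. Compound 2 gives 42.5 nM, a lower number whose gap to compound 1 lies beyond the usual scatter, so compound 2 is the stronger inhibitor of the pair. Compound 2 differs from compound 1 in more than one place, so that gap cannot be tied to a single change.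

Compound 3, `Cc1ccc(-c2ccc(CN3CCC(O)(Cn4cnc5c(-c6ccc(CN)cc6)n(C)nc5c4=O)CC3)c(Cl)c2)s1`, has not yet been measured. It differs from compound 1 in one place: 5-methylthiophen-2-yl in place of 1H-pyrrol-2-yl on an aromatic carbon. The ring that leaves brings a hydrogen-bond donor; the ring that enters brings a hydrogen-bond acceptor and a methyl group.

Among the compounds with values here, no measured step isolates this exchange, so the expectation is cautious. Compound 2, which also lacks the donor at that place, sits at the lower number, but its other difference blurs the lesson. The expected step is a 1.6-fold lower number from compound 1 to compound 3 (0.21 log units; within the scatter), a small move toward stronger inhibition in this assay that may not exceed the scatter. Compound 3 is therefore estimated at 120 nM, with a likely range from 40 nM to 350 nM.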

Compound 3, half-maximal inhibitory concentration: 101 nM
For compound 3 the middle estimate is 1.2-fold (0.07 log units) above the measured one; the measured number falls inside the stated range.
By their numbers in this assay, from the lowest: compound 2; then compounds 3 and 1 (each within the scatter of the next).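

In this assay, within the data shown here, the exchange of 1H-pyrrol-2-yl for 5-methylthiophen-2-yl gives a 1.9-fold lower number from compound 1 to compound 3 (0.28 log units; within the scatter), the first change in this set that can be read at a single place. On this aromatic carbon, para to a large group, a ring with no hydrogen-bond donor and an added methyl group therefore gives a number that cannot be told apart from that of the pyrrole compound, so in this pair the donor of the leaving ring is not required for inhibition to be measured at this level. Nothing measured here explains this outcome, and the step alone does not show whether the new ring atom, the lost donor and the added methyl group each have little effect or whether their effects offset one another.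

The contributions of the ring and the methyl group remain unseparated, and a plain thiophen-2-yl ring or a 5-methyl-1H-pyrrol-2-yl ring on the same core would pull them apart. How far this place tolerates change is also open, as a larger or charged group, such as an aminomethyl group on the thiophene ring, lies outside the compounds shown.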